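Nitro in Place of Dimethylamino on the Pendant Ring

A few compounds are considered here, and "the series" means these few. Any claim that something is new, unique, unknown or untested is made for them only; others in the source may bear on it.

Of the compounds shown here, two of a shared core have been measured in a functional assay (muscle tissue) with Cavia porcellus as the target; a lower number here means that less compound is needed, a higher number that more compound is needed for the effect. Compound 1 `COC(=O)C1=C(C)N=C(C)/C(=C(\O)OC)C1c1cccc(N(C)C)c1` gives 891 nM, the highest of the two numbers. Compound 2 `COC(=O)C1=C(C)N=C(C)/C(=C(\O)OC)C1c1c(Cl)cccc1Cl` gives 1.91 nM, a far lower number that lies well beyond the scatter of the method; compound 2 shows what this core can reach in this assay. Going by the values given here, no single-point step links these two.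

Compound 3 `COC(=O)C1=C(C)N=C(C)/C(=C(\O)OC)C1c1cccc([N+](=O)[O-])c1` differs from compound 1 in one place: nitro in place of dimethylamino on an aromatic carbon. The change sits on an aromatic carbon of a six-membered aromatic ring of carbon only, meta to a large group.

Because compound 1 stands at 891 nM while compound 2 reaches 1.91 nM, the author expects a clear step downward, beyond the scatter, for a 30-fold lower number from compound 1 to compound 3 (1.47 log units; beyond the scatter). For compound 3 the expected value in this assay is 30 nM, with a range from 3 nM to 300 nM.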

Compound 3, half-maximal effective concentration: 3.98 nM
The estimate for compound 3 lay 7.5-fold (0.88 log units) above the measured number; the range from low to high includes it.
By their numbers in this assay, from the lowest: compound 2; then compound 3; then compound 1.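

Replacing dimethylamino with nitro on this aromatic carbon, meta to a large group, gives a 220-fold lower number from compound 1 to compound 3 (2.35 log units; beyond the scatter) in this assay. This is the first single-point step among these compounds, and it shows that the number at this place depends strongly on the group carried there. The leaving and entering groups both have 3 heavy atoms, so the heavy-atom count alone does not separate them, and nothing available here explains the size of the step.

A single step cannot show whether the gain comes from having nitro at this place or from losing dimethylamino. As far as these compounds go, how a nitrile, a methoxy group, a carboxylic acid or a primary amine would read at this carbon remains open, as does the effect of nitro on another carbon of the ring.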